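The compounds below may be only part of what the source reports. "The series", "measured", "known", "first", "only" and "open" are said of these compounds alone.

Working notes on the series.

Compound 1 `CN1CCN(c2cc(C(F)(F)F)ccc2[C@H]2CCOc3cc(S(=O)(=O)Nc4nccs4)ccc32)CC1` is the reference for this step. Among the compounds with values here, in a physicochemical assay for solubility (on this read-out higher numbers stand for higher solubility and lower numbers for lower solubility), compound 1 gives 176000 nM, the lowest of the three numbers measured so far, though its gaps to the other two lie within the scatter. Compound 2 `Cc1nc(-c2cc(C(F)(F)F)ccc2[C@H]2CCOc3cc(S(=O)(=O)Nc4ncc(F)cn4)ccc32)co1` gives 281000 nM, and compound 3 `Cc1ccc(-c2cc(C(F)(F)F)ccc2[C@H]2CCOc3cc(S(=O)(=O)Nc4ncc(F)cn4)ccc32)cn1` gives 225000 nM. Within the data shown here, the only single-point step measured, a 1.2-fold lower number from compound 2 to compound 3 (0.10 log units; within the scatter), exchanges one aromatic ring for another at the same aromatic carbon that is changed in the step now under review.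

Compound 4 `O=S(=O)(Nc1nccs1)c1ccc2c(c1)OCC[C@@H]2c1ccc(C(F)(F)F)cc1-n1ccnn1` differs from compound 1 by 1H-1,2,3-triazol-1-yl in place of 4-methylpiperazin-1-yl on an aromatic carbon. Among the measured compounds shown here, no measured step covers this exchange; the step from compound 2 to compound 3 bears on it only loosely, since it also alters the group on that carbon and produced nothing beyond the scatter. The present change removes a six-membered non-aromatic ring with 2 hetero atoms and brings in a five-membered aromatic ring with 3 hetero atoms, a larger alteration than any measured. The expectation for compound 4 is therefore a step of a 2.2-fold lower number from compound 1 to compound 4 (0.34 log units; beyond the scatter), toward a lower number, with wide uncertainty. Compound 4 is estimated at 80000 nM, within 25000 nM to 250000 nM.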

Compound 4, solubility: 171000 nM
Estimate against measurement, compound 4: 2.1-fold (0.33 log units) below; low and high end bracket the measured number.
By their numbers in this assay, from the lowest: compounds 4, 1, 3 and 2 (each within the scatter of the next).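

Working notes, continued. In this assay, 1H-1,2,3-triazol-1-yl in place of 4-methylpiperazin-1-yl on this aromatic carbon, ortho to a large group and meta to a trifluoromethyl group, gives a 1.0-fold lower number from compound 1 to compound 4 (0.01 log units; within the scatter). The earlier step at this carbon exchanged one aromatic ring for another, whereas this one shows that a five-membered aromatic ring in place of a six-membered non-aromatic ring also stays within the scatter on this read-out. Nothing at hand explains this outcome.

From the compounds shown here alone, whether a primary amine or a carboxylic acid on this carbon would give a step beyond the scatter remains open. Going by these compounds, compounds 2 and 3 also carry a different group on the sulfonamide nitrogen from compounds 1 and 4, so it remains open whether the exchange of compound 1 for compound 4 would read the same with that other group.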